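A few compounds are considered here, and "the series" means these few. Any claim that something is new, unique, unknown or untested is made for them only; others in the source may bear on it.

Compound 2 `Cc1cccc(Cn2cc(CNC(=O)c3cnc(Nc4ccc(C#N)cc4)cc3Oc3c(C)cc(C)cc3C)nn2)c1` carries, on the saturated chain carbon bound to an aromatic nitrogen, a 3-methylbenzyl arm. Within the data shown here, in an ADME assay on MT4 cells (Homo sapiens) for cytotoxicity, read by MTT assay, with a stated time of 5 days (on this read-out higher numbers stand for lower toxicity in this test and lower numbers for higher toxicity in this test), compound 2 gives 114000 nM, the only number found among the two results. Compound 1 `Cc1cc(C)c(Oc2cc(Nc3ccc(C#N)cc3)ncc2C(=O)NCc2cn(Cc3ccccc3[N+](=O)[O-])nn2)c(C)c1` reaches only the limit > 212000 nM in this assay. Among the measured compounds shown here, the single measured step, an at least 1.8-fold lower number from compound 1 to compound 2 (0.26 log units; that floor lies within the scatter), rests on that limit, (the limit of > 212000 nM in this assay, at which 1 of the 2 values shown sits), and its floor stays within the scatter.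

Compound 3 `CCOC(=O)Cn1cc(CNC(=O)c2cnc(Nc3ccc(C#N)cc3)cc2Oc2c(C)cc(C)cc2C)nn1` differs from compound 2 by ethoxycarbonyl in place of 3-methylphenyl on a saturated chain carbon bound to an aromatic nitrogen. For the measured compounds named here, the only step bearing on this kind of exchange at that position is the one from compound 1 to compound 2, and it was small. No step beyond the scatter is therefore expected in this assay, a 1.1-fold higher number from compound 2 to compound 3 (0.06 log units; within the scatter). Compound 3 is estimated at 130000 nM, within 50000 nM to 320000 nM, with a fair chance that only a limit is reported.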

Compound 3, half-maximal cytotoxic concentration: 9530 nM
Beside the measured number, compound 3's estimate is 14-fold (1.13 log units) above it; the whole stated range lies above it.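

The saturated chain carbon bound to an aromatic nitrogen now proves able to shift the number in this assay, with lower numbers standing for higher toxicity in this test: ethoxycarbonyl in place of 3-methylphenyl gives a large step (a 12-fold lower number from compound 2 to compound 3 (1.08 log units; beyond the scatter)), whereas the earlier exchange between two aromatic groups had a floor within the scatter. Ethoxycarbonyl in place of 2-nitrophenyl is also large (an at least 22-fold lower number from compound 1 to compound 3 (1.34 log units; beyond the scatter)), so compound 3, with no ring in the entering group, stands apart from both ring-bearing compounds. That second step is only a floor, as the value of compound 1 is a limit and not a number: the limit of > 212000 nM in this assay, at which 1 of the 3 values shown sits.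

The compounds shown leave open whether the change goes with the loss of the ring or with the ethoxycarbonyl group itself. Going by these compounds, how a carboxylic acid, an amine or a plain ethyl chain would read at this place also remains open.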